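The compounds below may be only part of what the source reports. "The series", "measured", "known", "first", "only" and "open" are said of these compounds alone.

Working notes on the series.

Three compounds of the shared core have numbers in a functional assay on U-87MG ATCC cells (Homo sapiens) for cytotoxicity, read by MTT assay, with a stated time of 72 h; a lower number here means a stronger inhibitor, a higher number a weaker inhibitor. Compound 1 `COc1cc2c(Oc3ccc(NC(=O)c4nnn(-c5ccccc5C)c4C)cc3F)ccnc2cc1OCCCN1CCCC1` gives 1600 nM. Compound 2 `COc1cc2c(Oc3ccc(NC(=O)c4nnn(-c5ccccc5C(F)(F)F)c4C)cc3F)ccnc2cc1OCCCN1CCCC1` gives 1060 nM. Compound 3 `COc1cc2c(Oc3ccc(NC(=O)c4nnn(-c5ccc(F)cc5)c4C(F)(F)F)cc3F)ccnc2cc1OCCCN1CCCC1` gives 850 nM. Compound 2 thus has the second highest number of the three; its nearest neighbour is compound 3 and its furthest is compound 1, and both gaps lie within the scatter, so no order among the three can be claimed.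

The next compound, compound 4 `COc1cc2c(Oc3ccc(NC(=O)c4nnn(-c5ccccc5C(F)(F)F)c4C(F)(F)F)cc3F)ccnc2cc1OCCCN1CCCC1`, is reached from compound 2 by one change: trifluoromethyl in place of methyl on an aromatic carbon. For the measured compounds named here, one measured step bears on this kind of change, the same exchange on an aromatic carbon of the phenyl ring, where a 1.5-fold lower number from compound 1 to compound 2 (0.18 log units; within the scatter). Compound 3 carries the trifluoromethyl on the five-membered aromatic ring with 3 nitrogen, as compound 4 will, but differs from compound 2 in more than one place, so its number can only be set beside that of compound 2: the two lie within the scatter of each other.

On this basis no step beyond the scatter is expected in this assay. Compound 4 is estimated at 900 nM, with a range from 450 nM to 1800 nM. The expected step is a 1.2-fold lower number from compound 2 to compound 4 (0.07 log units; within the scatter).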

Compound 4, half-maximal inhibitory concentration: 1180 nM
Estimate against measurement, compound 4: 1.3-fold (0.12 log units) below, and the stated range covers the measured number.
By their numbers in this assay, from the lowest: compounds 3, 2, 4 and 1 (each within the scatter of the next).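

In this assay, the exchange of methyl for trifluoromethyl on an aromatic carbon of the five-membered aromatic ring with 3 nitrogen gives a 1.1-fold higher number from compound 2 to compound 4 (0.05 log units; within the scatter), so the exchange now has a reading at this position, next to the ring atom that bears a 2-(trifluoromethyl)phenyl group, and, like the same exchange on the phenyl ring, it stays within the scatter. Compound 4 also allows the group on the aromatic nitrogen to be read with trifluoromethyl held on the ring carbon: 2-(trifluoromethyl)phenyl in place of 4-fluorophenyl gives a 1.4-fold higher number from compound 3 to compound 4 (0.14 log units; within the scatter), again without a step that can be claimed. Nothing available on these compounds accounts for these readings, which stand only as numbers from the cell assay.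

All steps shown for this position and for the group on the aromatic nitrogen therefore remain within the scatter, and what a step beyond it would take is open. An amine, a carboxylic acid or a longer alkyl chain on this ring carbon, in place of methyl or trifluoromethyl, would test whether the number in this assay responds to this position at all.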